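Adding a Chloro Group to the Phenyl Ring of Compound 1

The source may hold more compounds than are shown below. What is called first, only, known or untested is meant among the compounds shown, and "the series" means these compounds.

Compound 1 `COc1ccc(-c2nc(SCC(=O)c3sc(-c4ccccc4)nc3C)[nH]c(=O)c2C#N)cc1`: 52.1%
Compound 2 `COc1cccc(-c2nc(SCC(=O)c3sc(-c4ccccc4)nc3C)[nH]c(=O)c2C#N)c1`: 80.3%

In a functional assay on U-87MG ATCC cells for antiproliferative activity against U-87 MG (Homo sapiens), read by MTT assay, with a stated time of 48 h, tested at 50 uM (a lower number here means a stronger effect, a higher number a weaker effect of the compound at the concentration tested), compound 1 gives 52.1%, the lowest of the two numbers shown. Among the measured compounds shown here, compound 2 gives 80.3%, and the one measured step, a number 28.2 percentage points higher from compound 1 to compound 2 (beyond the scatter), concerns the methoxy group on a different ring. Compound 3 `COc1ccc(-c2nc(SCC(=O)c3sc(-c4ccc(Cl)cc4)nc3C)[nH]c(=O)c2C#N)cc1` differs from compound 1 by chloro in place of hydrogen on an aromatic carbon, so that the unsubstituted phenyl becomes 4-chlorophenyl. For the measured compounds named here, no measured step touches this ring, so the step from compound 1 to compound 2 does not bear on it, and there is nothing in the numbers to suggest a change in either direction. The expectation is therefore a step of about none beyond the scatter, a number 0.1 percentage points lower from compound 1 to compound 3 (within the scatter), with wide uncertainty. For compound 3 the estimated value in this assay is 52%, expected to lie between 30% and 75%.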

Compound 3, a percentage reported as activity, at one concentration (the size of the read-out at that concentration, not a potency): 46.3%
Compound 3: the middle estimate sits 5.7 percentage points above what was measured; the measured number falls inside the stated range.
By their numbers in this assay, from the lowest: compounds 3 and 1 (each within the scatter of the next); then compound 2.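

In this assay, the phenyl ring accepts this change without a measurable effect: going to 4-chlorophenyl gives a number 5.8 percentage points lower from compound 1 to compound 3 (within the scatter), so the two compounds cannot be told apart. This contrasts with the earlier pair, where moving the methoxy group on a different ring gave a number 28.2 percentage points higher from compound 1 to compound 2 (beyond the scatter), so the core of compound 1 does not respond to every change in the same way. No available evidence explains why the chloro group makes so little difference.

On these data alone, whether a different group at this place on the phenyl ring, such as an amine or a carboxylic acid, would shift the number remains open. Also open, as far as these compounds go, is whether chloro on another carbon of that ring would leave the number as unchanged as 4-chlorophenyl does.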